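This account rests on a few compounds, and the source may have more. Where it says the series, first, only, none or still open, it means among the compounds named here.

Measured compounds in a functional assay on the whole organism (strain Swiss albino) for inhibition, with Mus musculus as the target, in the writhing test, with stated times of 60 min and 15 min, at a dose of 100 mg/kg by the oral route; on this read-out lower numbers stand for less inhibition and higher numbers for more inhibition at the one dose given (going by the name of the read-out):

compound 1, `COc1cc2c(cc1OC)C(CC(=O)O)CC2`: 44%
compound 2, `COc1cc2c(cc1OC)C(CC(N)=O)CC2`: 24.6%
compound 3, `CCCCNC(=O)CC1CCc2cc(OC)c(OC)cc21`: 39.4%

Compound 3 stands second highest of the three numbers in this assay. Its nearest neighbour is compound 1, whose value sits a number 4.6 percentage points lower from compound 1 to compound 3 (within the scatter); the gap to compound 2 is larger, a number 14.8 percentage points higher from compound 2 to compound 3 (beyond the scatter).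

The step to compound 4, `CCCCCCNC(=O)CC1CCc2cc(OC)c(OC)cc21`, is ethyl in place of hydrogen on a saturated chain carbon, four bonds along the chain from an amide-type nitrogen. Among the compounds with values here, no measured pair covers a change of this kind on the saturated chain. Within the data shown here, the only step touching the amide-type nitrogen substituent is butyl in place of hydrogen, a number 14.8 percentage points higher from compound 2 to compound 3 (beyond the scatter). The step from compound 1, amino in place of hydroxy on the carbonyl carbon, ran a number 19.4 percentage points lower from compound 1 to compound 2 (beyond the scatter), and butylamino in place of hydroxy ran a number 4.6 percentage points lower from compound 1 to compound 3 (within the scatter). Two of the three measured steps lie within scatter or are modest, and nothing measured speaks to extending the chain further. The expectation for this assay is therefore a step of a number 0.6 percentage points higher from compound 3 to compound 4 (within the scatter) from compound 3 to compound 4, not beyond the scatter. Compound 4 is estimated at 40%, with a range from 25% to 55%.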

Compound 4, a percentage reported as inhibition, in the whole organism at one dose (the size of the read-out at that dose, not a potency): 82.2%
Compound 4: middle estimate off by 42.2 percentage points, on the low side; the measured number lies above the stated range.
By their numbers in this assay, from the lowest: compound 2; then compounds 3 and 1 (each within the scatter of the next); then compound 4.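

In this assay, within the data shown here, ethyl in place of hydrogen on a saturated chain carbon, four bonds along the chain from the amide-type nitrogen, is a large step (by a number 42.8 percentage points higher from compound 3 to compound 4 (beyond the scatter)), so this outer part of the chain matters far more than the earlier compounds could show. Hexyl in place of hydrogen on the amide-type nitrogen also gives a larger step (by a number 57.6 percentage points higher from compound 2 to compound 4 (beyond the scatter)) than butyl did (by a number 14.8 percentage points higher from compound 2 to compound 3 (beyond the scatter)), and hexylamino in place of hydroxy on the carbonyl carbon is the first replacement to rise clear of the acid (by a number 38.2 percentage points higher from compound 1 to compound 4 (beyond the scatter)). Nothing at hand accounts for the size of this jump.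

As far as these compounds go, whether a longer chain, a branched chain or a chain ending in an amine keeps this level remains open. With a single dose, the read-out gives no potency for any of these compounds.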